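Replacing thiophen-2-yl in compound 2

This account rests on a few compounds, and the source may have more. Where it says the series, first, only, none or still open, it means among the compounds named here.

Of the compounds shown here, three have numbers so far in a functional assay on NT2 cells (Homo sapiens) for inhibition (on this read-out higher numbers stand for weaker inhibition and lower numbers for stronger inhibition), and all sit at low values. Compound 2 `CCC(C(=O)N[C@@H](CC(=O)O)C(=O)CSCc1ccccc1)n1ccnc(NCc2cccs2)c1=O` gives 4.56 nM and is the weakest of the three. Compound 3 `CCC(C(=O)N[C@@H](CC(=O)O)C(=O)CNCN1CCC(Cc2ccccc2)CC1)n1ccnc(NCc2nonc2C)c1=O` is nearest at 1.62 nM and compound 1 `CCCCCCN(C)CNCC(=O)[C@H](CC(=O)O)NC(=O)C(CC)n1cc(C(C)(CC)CC)nc(NCc2nonc2C)c1=O` is furthest at 0.025 nM with both gaps beyond the scatter.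

Compound 4 `CCC(C(=O)N[C@@H](CC(=O)O)C(=O)CSCc1ccccc1)n1ccnc(NCc2nc(C)no2)c1=O` keeps the rest of compound 2 and carries 3-methyl-1,2,4-oxadiazol-5-yl in place of thiophen-2-yl on a saturated chain carbon bound to a nitrogen on an aromatic ring. Among the compounds with values here, no measured pair isolates this change, and compounds 1 and 3 differ from compound 2 in more than one place. The evidence for any direction is therefore thin. A small move toward stronger inhibition in this assay is expected, but none beyond the scatter: the estimated step is a 1.5-fold lower number from compound 2 to compound 4 (0.18 log units; within the scatter) and it remains a tentative expectation. For compound 4 the estimated value is 3 nM with an expected range of 0.8 nM to 11 nM in this read-out.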

Compound 4, half-maximal inhibitory concentration: 5.33 nM
Compound 4: the middle estimate sits 1.8-fold (0.25 log units) below what was measured; low and high end bracket the measured number.
By their numbers in this assay, from the lowest: compound 1; then compound 3; then compounds 2 and 4 (each within the scatter of the next).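

Swapping thiophen-2-yl for 3-methyl-1,2,4-oxadiazol-5-yl gives the only single-place comparison so far in this assay, and a 1.2-fold higher number from compound 2 to compound 4 (0.07 log units; within the scatter) lies within the scatter. On a saturated chain carbon bound to a nitrogen on an aromatic ring, a five-membered aromatic ring with 1 hetero atom and one with 3 hetero atoms therefore cannot be told apart in this read-out, at least with the rest of compound 2 held fixed. No available evidence bears on this result.

From the compounds shown here alone, whether the same swap reads alike on the backgrounds of compound 1 or compound 3 stays open, as those compounds differ from compound 2 in more than one place. Also open, going by these compounds, is how a phenyl ring or a longer chain would read at this place, and whether an amine in place of the sulfur-linked benzyl end would change the number for compound 4.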